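Clearance notes on the step to compound 4

The compounds below may be only part of what the source reports. "The series", "measured", "known", "first", "only" and "open" are said of these compounds alone.

compound 1 `CN1C[C@H](C(=O)Nc2ccc(C#N)cc2)[C@@H](c2ccc(/C=C/C(=O)Nc3ccccc3N)cc2)C1` gives 35 mL/min/kg
compound 2 `CN1C[C@H](C(=O)Nc2ccc(Br)cc2)[C@@H](c2ccc(/C=C/C(=O)Nc3ccccc3N)cc2)C1` gives 16 mL/min/kg
compound 3 `CN1C[C@H](C(=O)Nc2cccc(F)c2)[C@@H](c2ccc(/C=C/C(=O)Nc3ccccc3N)cc2)C1` gives 56 mL/min/kg
compound 4 `Cc1cc(NC(=O)[C@H]2CN(C)C[C@@H]2c2ccc(/C=C/C(=O)Nc3ccccc3N)cc2)ccc1F` is not yet measured

In an in vitro ADME assay on microsomes from liver (Mus musculus) for pharmacokinetics, read by LC-MS, with a stated time of 10 min, tested at 1 uM (a lower number here means slower removal, a higher number faster removal of the compound), compound 3 sits at the high end of the three numbers. The gap to its nearest neighbour is a 1.6-fold higher number from compound 1 to compound 3 (0.20 log units; within the scatter), and the gap to its furthest is a 3.5-fold higher number from compound 2 to compound 3 (0.54 log units; beyond the scatter).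

The structural change is 4-fluoro-3-methylphenyl in place of 3-fluorophenyl on an amide-type nitrogen. Among the measured compounds shown here, no measured step makes this exact swap. The closest evidence is the pair of other swaps on that nitrogen. Only 4-bromophenyl stands clearly apart from 3-fluorophenyl, while 4-cyanophenyl does not, and a 2.2-fold lower number from compound 1 to compound 2 (0.34 log units; beyond the scatter) separates those two rings. Steps at this place have thus been modest or smaller, and three compounds are thin support for any trend.

A small move to a lower number is expected, resting on compound 1 at 35 mL/min/kg and compound 2 at 16 mL/min/kg, and it may not clear the scatter. The estimated change is a 1.6-fold lower number from compound 3 to compound 4 (0.19 log units; within the scatter) and remains an expectation only. Compound 4 is estimated at 36 mL/min/kg, with an expected range from 17 mL/min/kg to 70 mL/min/kg in this assay.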

Compound 4, clearance: 62 mL/min/kg
Compound 4: middle estimate off by 1.7-fold (0.24 log units), on the low side; the range from low to high includes it.
By their numbers in this assay, from the lowest: compound 2; then compounds 1, 3 and 4 (each within the scatter of the next).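

In this assay, 4-fluoro-3-methylphenyl on the amide-type nitrogen cannot be told apart from 3-fluorophenyl, with a 1.1-fold higher number from compound 3 to compound 4 (0.04 log units; within the scatter), or from 4-cyanophenyl, with a 1.8-fold higher number from compound 1 to compound 4 (0.25 log units; within the scatter), so the extra methyl carbon counted in this ring gives no readable step here. The separation at this position now rests on compound 2 alone, since a 3.9-fold higher number from compound 2 to compound 4 (0.59 log units; beyond the scatter) joins its two earlier steps in lying beyond the scatter, leaving 4-bromophenyl as the only ring among the four that stands apart, with the lowest number. Nothing at hand bears on why that one ring stands apart from the other three.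

The two fluorinated rings differ both by the methyl and by where the fluorine sits, so 4-fluorophenyl and 3-fluoro-5-methylphenyl on the same nitrogen would be needed to separate those two differences. From the compounds shown here alone, it also remains open whether the low number of compound 2 belongs to bromine in particular or extends to rings such as 4-chlorophenyl or 4-iodophenyl, and how a ring carrying a carboxylic acid or an amine would read.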